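The source may hold more compounds than are shown below. What is called first, only, known or untested is meant among the compounds shown, and "the series" means these compounds.

Measured so far in a functional assay on SMMC-7721 cells (Homo sapiens) for cytotoxicity, read by MTT assay, with a stated time of 4 days; on this read-out higher numbers stand for weaker inhibition and lower numbers for stronger inhibition:
compound 1 `C=C1C[C@]23C[C@@]1(O)CC[C@H]2c1ccc(OS(=O)(=O)c2ccc(C)cc2)c(C)c1[C@@H]3Cn1cc(-c2ccc(Br)cc2)nn1` gives > 20000 nM, which is a limit of the assay and not a number.
compound 2 `C=C1C[C@]23C[C@@]1(O)CC[C@H]2c1ccc(O)c(C)c1[C@@H]3Cn1cc(-c2ccc(Br)cc2)nn1` gives > 20000 nM, again a limit of the assay.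
compound 3 `C=C1C(=O)[C@]23C[C@@]1(O)CC[C@H]2c1ccc(O)c(C)c1[C@@H]3Cn1cc(-c2ccc(Cl)cc2)nn1` gives 670 nM.

Compound 1 thus stands only as a limit; it sits at the limit of > 20000 nM in this assay, at which 2 of the 3 values shown sit. Among the compounds with values here, the single step measured between compounds that differ in one place, a step that the two limits leave unreadable from compound 1 to compound 2, cannot be read, because both of its ends are limits. Compound 3 is the only compound with a number, but it differs from compound 1 in more than one place, and no step to it is shown.

Compound 4 `C=C1C[C@]23C[C@@]1(O)CC[C@H]2c1ccc(OS(=O)(=O)c2ccc(C)cc2)c(C)c1[C@@H]3Cn1cc(-c2ccccn2)nn1` differs from compound 1 by pyridin-2-yl in place of 4-bromophenyl on an aromatic carbon. Within the data shown here, none of the measured steps bears on this change: neither compound 2 nor compound 3 alters the group on the five-membered aromatic ring with 3 nitrogen in the way compound 4 does. With compound 1 at a limit, neither the direction nor the size of the step can be set from the data shown. The expected step that the limit leaves unreadable from compound 1 to compound 4 is therefore placed near zero, with a wide range. Compound 4 is expected to give 25000 nM in this assay, between 5000 nM and 100000 nM, most likely reported again as a limit.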

Compound 4, half-maximal inhibitory concentration: > 20000 nM
Compound 4 gave a limit, no number (the forecaster's own chance of this, stated with the estimate: 80%); the middle value is on the limit's open side.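

In this assay compound 4 gives > 20000 nM, which is a limit of the assay and not a number. Compound 1 also stands only as a limit, so no step between compound 1 and compound 4 can be read: the limit of > 20000 nM in this assay, at which 3 of the 4 values shown sit.

The compounds shown leave open in which direction, and how far, pyridin-2-yl in place of 4-bromophenyl moves the read-out.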